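Aryl-pyridine series: moving the pyridyl nitrogen

A few compounds are considered here, and "the series" means these few. Any claim that something is new, unique, unknown or untested is made for them only; others in the source may bear on it.

The series is a set of three aryl-substituted pyridine cores carrying a hydroxyphenyl group, a 4-chlorophenyl group and a second pyridyl ring. Among the measured compounds shown here, compound 1 `Oc1cccc(-c2cc(-c3ccc(Cl)cc3)nc(-c3ccccn3)c2)c1` is the only member with a number: in a functional assay on HCT-15 cells (Homo sapiens) for cytotoxicity, read by CCK-8 assay and cell counting, with a stated time of 2 days (on this read-out higher numbers stand for weaker inhibition and lower numbers for stronger inhibition), compound 1 gives 13500 nM, a weak result. Compound 2 `Oc1ccc(-c2cc(-c3ccncc3)nc(-c3ccc(Cl)cc3)c2)cc1` has no single number in this assay; the read-out for compound 2 is recorded as "not determined" (no result reported), so compound 2 stands nowhere on the measured scale and offers no anchor of its own.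

Compound 3 `Oc1ccc(-c2cc(-c3ccc(Cl)cc3)nc(-c3ccccn3)c2)cc1` is the next member, to be measured in this assay. Against compound 2 the change is pyridin-2-yl in place of pyridin-4-yl on an aromatic carbon. For the measured compounds named here, no step between measured compounds is available, so the size of this change in this assay cannot be read from precedent; no shift beyond the scatter is assumed in either direction, and the expectation rests on the weak result of compound 1, which gives 13500 nM.

Compound 3 is therefore expected to come out near 12000 nM in this assay, with a range from 3000 nM to 50000 nM.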

Compound 3, half-maximal inhibitory concentration: 21300 nM
Beside the measured number, compound 3's estimate is 1.8-fold (0.25 log units) below it; low and high end bracket the measured number.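

In this assay, 4-hydroxyphenyl in place of 3-hydroxyphenyl on an aromatic carbon gives a 1.6-fold higher number from compound 1 to compound 3 (0.20 log units; within the scatter), so this swap does not separate the two compounds on this read-out. The other change, pyridin-2-yl in place of pyridin-4-yl, cannot be read: compound 2 carries no number, and the placing of the pyridyl nitrogen therefore has no measured size in this series. No measured data on hand explain the result.

The compounds shown leave open how a methoxy group, an amine or a carboxylic acid would read in this assay in place of the hydroxyl on the hydroxyphenyl ring, and so whether that ring's substituent matters at all on this read-out. Also open, from the compounds shown here alone, are how pyridin-3-yl would read in place of pyridin-2-yl on the core of compound 3, and whether a bromine or a methyl group in place of the chlorine on the 4-chlorophenyl group would shift the number beyond the usual scatter.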